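The source may hold more compounds than are shown below. What is called first, only, known or untested is meant among the compounds shown, and "the series" means these compounds.

Measured so far in the series:

compound 1, `Cc1ccc(=O)n(CCCCCCC(=N)S)n1`, 29.5%
compound 2, `Cc1ccc(=O)n(CCCCC(=N)S)n1`, 29.5%, which matches compound 1 at 29.5%
compound 3, `N=C(S)CCCCN1N=C(c2ccccc2)CCC1=O`, 50.2%

All three numbers come from a functional assay on the whole organism (stomach) for inhibition, with Rattus norvegicus as the target, at a dose of 100 mg/kg by the intraduodenal route; a lower number here means less inhibition, a higher number more inhibition at the dose given (going by the name of the read-out). Compound 1 and compound 2 share a core and differ in one place only: a group of 3 heavy atoms (1 carbon, 1 nitrogen, 1 sulfur; no ring) in place of a group of 5 heavy atoms (3 carbon, 1 nitrogen, 1 sulfur; no ring), on a saturated chain carbon, four bonds along the chain from an aromatic nitrogen. The step of no change at the digits printed from compound 1 to compound 2 (within the scatter) shows that this shortening of the chain left the read-out unchanged within the scatter. Compound 3 carries a different core; the difference between the core of compound 3 and the core of compound 1 is not broken down here. In this assay compound 3 gives 50.2%, which stands beyond the scatter above both compound 1 and compound 2.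

Compound 4, `N=C(S)CCN1N=C(c2ccccc2)CCC1=O`, is not yet measured. It relates to compound 3 as compound 2 relates to compound 1: a group of 3 heavy atoms (1 carbon, 1 nitrogen, 1 sulfur; no ring) in place of a group of 5 heavy atoms (3 carbon, 1 nitrogen, 1 sulfur; no ring), on a saturated chain carbon, two bonds along the chain from an amide-type nitrogen in a ring. Within the data shown here, the change is the same kind of change as the one from compound 1 to compound 2, not the same: there the place was four bonds along the chain from an aromatic nitrogen, here it is two bonds along the chain from an amide-type nitrogen in a ring. Among the measured compounds shown here, the expectation for compound 3 to compound 4 rests on the one earlier instance: because no change at the digits printed from compound 1 to compound 2 (within the scatter) was flat, the expected step of a number 4.2 percentage points lower from compound 3 to compound 4 (within the scatter) is taken as small, though the different core and the shorter chain leave room for a wider spread. Compound 4 is estimated to give 46% in this assay, with a range from 26% to 66%.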

Compound 4, a percentage reported as inhibition, in the whole organism at one dose (the size of the read-out at that dose, not a potency): 38.2%
Compound 4: the middle estimate sits 7.8 percentage points above what was measured; low and high end bracket the measured number.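

In this assay, the same shortening of the chain on the core of compound 3 gives a number 12 percentage points lower from compound 3 to compound 4 (beyond the scatter), whereas on the core of compound 1 it gives no change at the digits printed from compound 1 to compound 2 (within the scatter). Set side by side, the two steps cannot be told apart: the same change on two cores in this assay, no change at the digits printed (within the scatter) from compound 1 to compound 2 and a number 12 percentage points lower (beyond the scatter) from compound 3 to compound 4, 12 percentage points apart, within the scatter of two such steps This shows only that the series offers no firm sign of the core altering the effect of the change; it does not show that the change carries over with the same size, since each core supplies a single pair, and the place also differs, four bonds along the chain from an aromatic nitrogen in one pair and two bonds along the chain from an amide-type nitrogen in a ring in the other.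

Still open, going by these compounds, is whether a chain longer than that of compound 3, on the same core, would continue the direction seen from compound 3 to compound 4 in this assay. Also open, on these data alone, is how an amine or a carboxylic acid would read out in place of the sulfur-bearing group at the end of the chain, and whether the step from shortening the chain would hold on a third core.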